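The source may hold more compounds than are shown below. What is called first, only, known or untested is meant among the compounds shown, and "the series" means these compounds.

Three compounds built on one shared core, compound 1 `Cc1ccc(Cn2cc(COc3ccc4c(=O)ccoc4c3)nn2)cc1`, compound 2 `O=c1ccoc2cc(OCc3cn(Cc4cccc(Cl)c4)nn3)ccc12` and compound 3 `O=c1ccoc2cc(OCc3cn(Cc4ccccc4Cl)nn3)ccc12`, have been tested in a functional assay on SW480 cells (Homo sapiens) for cytotoxicity, read by MTT assay, with a stated time of 48 h; a higher number here means a weaker inhibitor, a lower number a stronger inhibitor. Compound 1 gives 10400 nM, compound 2 gives 12900 nM, and compound 3 gives 23500 nM, the highest number of the three. The steps leading to it were a 2.3-fold higher number from compound 1 to compound 3 (0.35 log units; beyond the scatter) and a 1.8-fold higher number from compound 2 to compound 3 (0.26 log units; within the scatter). Compound 4 `N#Cc1ccc(Cn2cc(COc3ccc4c(=O)ccoc4c3)nn2)cc1` differs from compound 3 by 4-cyanophenyl in place of 2-chlorophenyl on a saturated chain carbon bound to an aromatic nitrogen. For the measured compounds named here, no measured step exchanges a chlorine for a nitrile, so the only guide is that compound 1, carrying 4-methylphenyl at the same place, gave the lowest number. A modest drop is therefore expected, a 1.7-fold lower number from compound 3 to compound 4 (0.22 log units; within the scatter). Compound 4 is estimated at 14000 nM, within 6000 nM to 35000 nM.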

Compound 4, half-maximal inhibitory concentration: > 100000 nM
Compound 4 gave a limit, no number; the forecaster's own chance of this, stated with the estimate: 10%; middle value at least 7.1-fold (0.85 log units) from the limit.
By their numbers in this assay, from the lowest: compounds 1, 2 and 3 (each within the scatter of the next, the first and the last beyond it). At a limit, above all of these: compound 4.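

In this assay, the reading for compound 4 is a limit, not a number: the limit of > 100000 nM in this assay, at which 1 of the 4 values shown sits. The earlier compounds shown here showed only modest differences at this place, but 4-cyanophenyl gives an at least 4.2-fold higher number from compound 3 to compound 4 (0.62 log units; beyond the scatter) and an at least 7.7-fold higher number from compound 2 to compound 4 (0.88 log units; beyond the scatter). The cleanest comparison is an at least 9.6-fold higher number from compound 1 to compound 4 (0.98 log units; beyond the scatter), since only cyano in place of methyl on an aromatic carbon separates them, so this single change can cost much of the cytotoxicity seen here.

As far as these compounds go, how far compound 4 lies past its limit remains open. So does whether an amine or a carboxylic acid in place of the cyano group would behave in the same way.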